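An aminophenyl group on a so far inactive core

A few compounds are considered here, and "the series" means these few. Any claim that something is new, unique, unknown or untested is made for them only; others in the source may bear on it.

In a functional assay on KYSE-410 cells (Homo sapiens) for antiproliferative activity, read by MTT assay, with a stated time of 72 h (on this read-out lower numbers stand for stronger inhibition and higher numbers for weaker inhibition), compound 1 `O=C(Nc1cccc(F)c1)c1cc(=O)[nH]c2cc(F)ccc12` gives > 20000 nM, which is a limit. Compound 2 `O=C(Nc1cccc(F)c1)c1cc(=O)[nH]c2cc(-c3ccccc3F)ccc12` gives > 20000 nM, also a limit. Compound 3 `O=C(Nc1cccc(F)c1)c1cc(=O)[nH]c2cc(C3CC3)ccc12` gives > 20000 nM, again a limit. The series therefore shows (the limit of > 20000 nM in this assay, at which 3 of the 3 values shown sit). Compound 4 `Nc1ccc(-c2ccc3c(C(=O)Nc4cccc(F)c4)cc(=O)[nH]c3c2)cc1` differs from compound 3 by 4-aminophenyl in place of cyclopropyl on an aromatic carbon, with 4-aminophenyl in place of cyclopropyl on an aromatic carbon. Three measured changes at this place bear on it: a step that the two limits leave unreadable from compound 1 to compound 2, a step that the two limits leave unreadable from compound 1 to compound 3 and a step that the two limits leave unreadable from compound 2 to compound 3. None of them gives a size to carry over. Compound 2, with its 2-fluorophenyl group, shows only the limit > 20000 nM, so only a small gain towards stronger inhibition is expected in this assay. The expected change is an at least 1.3-fold lower number from compound 3 to compound 4 (0.12 log units; that floor lies within the scatter), and a further limit remains quite possible. Compound 4 is expected at 15000 nM, with an estimated range of 3000 nM to 40000 nM.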

Compound 4, half-maximal inhibitory concentration: > 20000 nM
Compound 4: a limit, no number; the forecaster's own chance of this, stated with the estimate: 55%; middle value at least 1.3-fold (0.12 log units) from the limit.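

Compound 4 gives > 20000 nM, again a limit, so its steps from compound 1, compound 2 and compound 3 cannot be read: the limit of > 20000 nM in this assay, at which 4 of the 4 values shown sit. The compounds shown leave open whether any group at this place on the shared core gives a measurable value in this assay.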